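Swapping the benzylic aryl group on a propanamide core

The source may report more compounds than this note shows. Statements on the series, on what has been measured and on what is new or still open speak of the compounds shown alone.

Of the compounds shown here, three have been measured in a functional assay on CHO cells for antagonist activity at transient receptor potential cation channel subfamily V member 1 (Rattus norvegicus); on this read-out higher numbers stand for weaker inhibition and lower numbers for stronger inhibition. Compound 1 `CC(C)(C)c1ccc(CNC(=O)C2(c3ccc(NS(C)(=O)=O)cc3)CC2)cc1` gives 1770 nM, compound 2 `CC(NC(=O)/C=C/c1ccc(C(C)(C)C)cc1)c1ccc(NS(C)(=O)=O)c(F)c1` gives 23.9 nM, and compound 3 `CC(C(=O)NCc1ccc(Cl)c(Cl)c1)c1ccc(NS(C)(=O)=O)c(F)c1` gives 115 nM. Among these three numbers compound 3 holds the second highest; its nearest neighbour is compound 2, whose number is lower by a margin beyond the usual scatter, and its furthest is compound 1, whose number is higher, again beyond the scatter.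

Compound 4 `CC(C)c1ccc(CNC(=O)C(C)c2ccc(NS(C)(=O)=O)c(F)c2)cc1` differs from compound 3 in one place: 4-isopropylphenyl in place of 3,4-dichlorophenyl on a saturated chain carbon bound to an amide-type nitrogen. For the measured compounds named here, no measured pair in this set isolates that exact change, so the expectation rests on the general picture that compound 2, which also carries a branched alkyl on its aryl ring, sits at the stronger end of this assay with 23.9 nM, while compound 1 shows that a different core can undo such an advantage with 1770 nM.

For compound 4 a modest move toward stronger inhibition is expected, so that the step from compound 3 to compound 4 is estimated at a 1.4-fold lower number from compound 3 to compound 4 (0.16 log units; within the scatter) in this assay. Compound 4 is therefore expected to give about 80 nM in this assay, with a plausible range from 25 nM to 250 nM.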

Compound 4, inhibition constant: 144 nM
Compound 4: middle estimate off by 1.8-fold (0.26 log units), on the low side; the measured number falls inside the stated range.
By their numbers in this assay, from the lowest: compound 2; then compounds 3 and 4 (each within the scatter of the next); then compound 1.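

In this assay, 4-isopropylphenyl in place of 3,4-dichlorophenyl on a saturated chain carbon bound to an amide-type nitrogen gives a 1.3-fold higher number from compound 3 to compound 4 (0.10 log units; within the scatter) and so leaves no difference that this measurement can separate. For the compounds shown here, this is the first pair in the set that differs in one place, and it shows that an aryl group carrying only carbon and one carrying two chlorine atoms read the same here. Nothing measured in this set explains that match.

Going by these compounds, it remains open whether this position would still read the same with an amine or a carboxylic acid in place of the isopropyl group. Also open, on these data alone, is whether the same swap would behave this way on the core of compound 1 or compound 2.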